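A few compounds are considered here, and "the series" means these few. Any claim that something is new, unique, unknown or untested is made for them only; others in the source may bear on it.

Working notes on the benzyl sulfoxide series. The measure is an ADME assay; a higher number here means that the compound lasts longer, a lower number that the compound disappears faster. Compound 1, `COc1ccc(C[S+]([O-])c2ncccc2C(=O)Nc2ccncc2)c(OC)c1OC`, gives 0.45 h in this assay. Compound 2, `COc1cc(C)c(C[S+]([O-])c2ncccc2C(=O)Nc2ccncc2)c(OC)c1`, returns only a limit of the assay, < 0.02 h. Compound 3, `CCOc1cc(OC)ccc1C[S+]([O-])c1ncccc1C(=O)Nc1ccncc1`, likewise returns only a limit, < 0.02 h, so compound 3 stands at the floor of what the assay reports, as noted in the limit of < 0.02 h in this assay, at which 2 of the 3 values shown sit. Compound 4, `COc1ccc(C[S+]([O-])c2ncccc2C(=O)Nc2ccncc2)c(OC)c1`, is not yet measured; it differs from compound 3 by hydrogen in place of methyl on a saturated chain carbon bound to an oxygen on an aromatic ring. Going by the values given here, no measured pair isolates this change, so the step from compound 3 to compound 4 in this assay is expected to be small, upward if anything, and likely within the scatter: an at least 2.0-fold higher number from compound 3 to compound 4 (0.30 log units; that floor lies within the scatter). Compound 4 is thus estimated at 0.04 h, between 0.01 h and 0.2 h.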

Compound 4, half-life: < 0.02 h
Compound 4: a limit, no number; the forecaster's own chance of this, stated with the estimate: 45%; at least 2.0-fold (0.30 log units) between middle value and limit.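

Hydrogen in place of methoxy on an aromatic carbon gives, in this assay, an at least 22-fold lower number from compound 1 to compound 4 (1.35 log units; beyond the scatter), so this methoxy carries a step beyond the scatter, the first that can be read in the series. Compound 1 remains the only compound shown with a value that is a number. The steps to compound 4 from compound 2 and compound 3 cannot be read, because all three compounds sit at a limit: the limit of < 0.02 h in this assay, at which 3 of the 4 values shown sit.

From the compounds shown here alone, the true size of the step from compound 1 stays open, as compound 4 gives only a limit. Also open, going by these compounds, is whether fluorine or an amine on that aromatic carbon would hold the half-life as methoxy does.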